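The source may report more compounds than this note shows. Statements on the series, on what has been measured and on what is new or still open speak of the compounds shown alone.

Measured in a physicochemical assay for lipophilicity; on this read-out higher numbers stand for higher lipophilicity and lower numbers for lower lipophilicity
- compound 1 `Brc1ccccc1OCc1nc2ccccc2[nH]1` gives 3.51
- compound 2 `Brc1cccc(Br)c1OCc1nc2ccccc2[nH]1` gives 4.42

Compound 1 holds the lower of the two numbers. Unmeasured compound 3 `Clc1ccccc1OCc1nc2ccccc2[nH]1` differs from it by chloro in place of bromo on an aromatic carbon, with chloro in place of bromo on an aromatic carbon, ortho to a large group. Among the measured compounds shown here, one measured step bears on this, and only indirectly: bromo in place of hydrogen gave a number 0.91 log units higher from compound 1 to compound 2 (beyond the scatter), a modest rise. For the measured compounds named here, no chloro compound has been measured yet. A much smaller, downward change is therefore expected, with the estimated step of a number 0.16 log units lower from compound 1 to compound 3 (within the scatter) probably staying within the scatter. For compound 3 the estimated value is 3.35, with an expected range from 3.05 to 3.65.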

Compound 3, partition coefficient: 3.33
For compound 3 the middle estimate is 0.02 log units above the measured one, within the range that was stated.
By their numbers in this assay, from the lowest: compounds 3 and 1 (each within the scatter of the next); then compound 2.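

In this assay, chloro in place of bromo on an aromatic carbon, ortho to a large group, gives a number 0.18 log units lower from compound 1 to compound 3 (within the scatter) and so leaves the two compounds inseparable on this read-out. Among the compounds shown here, the earlier step, a number 0.91 log units higher from compound 1 to compound 2 (beyond the scatter) for bromo in place of hydrogen, added a halogen, whereas this is the first exchange of one halogen for another, and at this position the choice between the two does not register. Going by these compounds, whether an amine or a methoxy group in place of bromo at this position would shift the number as little stays open. What lies behind the closeness of these two compounds also stays open, with no supporting data at hand.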